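The source may hold more compounds than are shown below. What is called first, only, known or untested is meant among the compounds shown, and "the series" means these compounds.

Compounds measured so far in a functional assay on DU-145 cells (Homo sapiens) for cytotoxicity, in the presence of a further agent that is not named here; a lower number here means a stronger inhibitor, a higher number a weaker inhibitor:

compound 1, `Clc1cccc(-c2cc(-c3ccc(Cl)o3)cc(-c3cccs3)n2)c1` — 18100 nM
compound 2, `Clc1ccc(-c2cc(-c3cccnc3)nc(-c3cccs3)c2)o1` — 13000 nM
compound 3, `Clc1ccc(-c2cc(-c3ccsc3)nc(-c3ccccn3)c2)o1` — 10900 nM

All three values sit close together. Compound 3 gives the lowest number of the three, but its gap to compound 2 and its gap to compound 1 are both within the scatter, so no ordering among them can be claimed.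

The next compound, compound 4 `Cc1ccc(-c2cc(-c3ccc(Cl)o3)cc(-c3ccsc3)n2)cc1`, differs from compound 3 in one place: 4-methylphenyl in place of pyridin-2-yl on an aromatic carbon

Among the measured compounds shown here, only one measured step bears on this change, and only loosely: a 1.4-fold lower number from compound 1 to compound 2 (0.14 log units; within the scatter). That step exchanges a chlorophenyl group for a pyridyl group on the shared core and does not shift the number beyond the scatter. The present change again exchanges a pyridyl group for a substituted phenyl group, in the opposite sense, so the expectation is a step of a 1.2-fold higher number from compound 3 to compound 4 (0.08 log units; within the scatter), that is, nothing beyond the scatter in this assay. On this basis compound 4 is estimated at 13000 nM, with a range from 5000 nM to 35000 nM.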

Compound 4, half-maximal inhibitory concentration: 21200 nM
The estimate for compound 4 lay 1.6-fold (0.21 log units) below the measured number; measured number inside the range.
By their numbers in this assay, from the lowest: compounds 3, 2, 1 and 4 (each within the scatter of the next).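

In this assay, the exchange at this position, next to the ring nitrogen, gives a 1.9-fold higher number from compound 3 to compound 4 (0.29 log units; within the scatter), so a ring of carbon only bearing a methyl group takes the place of a ring with one nitrogen without a shift beyond the scatter. This is the first change shown at this position with the thiophen-3-yl group in place, and the loss of the ring nitrogen and its hydrogen-bond acceptor leaves no readable effect on the number here. No measurement is at hand that would explain the step.

The compounds shown leave open whether an unsubstituted phenyl ring would separate the contributions of the ring nitrogen and the methyl group. They also leave open whether an amine, a carboxylic acid or a longer chain at this position would move the number beyond the scatter.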